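This account rests on a few compounds, and the source may have more. Where it says the series, first, only, none or still open, it means among the compounds named here.

In a functional assay on B16-F0 cells (Mus musculus) for inhibition, read by CCK-8 assay, with a stated time of 48 h (on this read-out lower numbers stand for stronger inhibition and higher numbers for weaker inhibition), compound 1 (`COc1cc(-c2ccnc3cc(-c4c[nH]c5ccccc45)nn23)cc(OC)c1OC`) gives 40 nM, compound 2 (`COc1cc(-c2ccnc3cc(-c4ccccc4)nn23)cc(OC)c1OC`) gives 4730 nM and compound 3 (`COc1cc(-c2ccnc3cc(-c4ccc(N(C)C)cc4)nn23)cc(OC)c1OC`) gives 702 nM, the second highest of the three numbers. Compound 4 (`COc1ccc(-c2cc3nccc(-c4cc(OC)c(OC)c(OC)c4)n3n2)cc1F`) has 3-fluoro-4-methoxyphenyl in place of 4-(dimethylamino)phenyl on an aromatic carbon. The nearest evidence is the modest 6.7-fold lower number from compound 2 to compound 3 (0.83 log units; beyond the scatter), for dimethylamino in place of hydrogen. The large 120-fold higher number from compound 1 to compound 2 (2.07 log units; beyond the scatter) and the large 18-fold higher number from compound 1 to compound 3 (1.24 log units; beyond the scatter) both remove 1H-indol-3-yl, which compound 4 also lacks. Among the compounds with values here, no measured step tests the new group, so in this assay no step beyond the scatter is expected, with a slight lean towards a higher number. The expected step is a 1.4-fold higher number from compound 3 to compound 4 (0.15 log units; within the scatter). For compound 4 the estimated value is 1000 nM, with an expected range of 280 nM to 3600 nM.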

Compound 4, half-maximal inhibitory concentration: 3950 nM
Estimate against measurement, compound 4: 4.0-fold (0.60 log units) below; measured number outside the range, above it.
By their numbers in this assay, from the lowest: compound 1; then compound 3; then compounds 4 and 2 (each within the scatter of the next).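

In this assay, substitution on the phenyl ring does not always shift the number: compound 4 stays level with unsubstituted compound 2 (a 1.2-fold lower number from compound 2 to compound 4 (0.08 log units; within the scatter)), whereas the 4-(dimethylamino)phenyl of compound 3 stands apart (a 5.6-fold higher number from compound 3 to compound 4 (0.75 log units; beyond the scatter)). Neither substituted phenyl comes near the 1H-indol-3-yl of compound 1 (a 99-fold higher number from compound 1 to compound 4 (1.99 log units; beyond the scatter)). No measurement shown accounts for these differences.

Open, from the compounds shown here alone, is whether a 1-methylindol-3-yl or naphthyl group at this place would stay near compound 1, and whether a simple 4-aminophenyl would follow compound 3.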